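A few compounds are considered here, and "the series" means these few. Any claim that something is new, unique, unknown or untested is made for them only; others in the source may bear on it.

Measured so far in an assay on isolated protein for agonist activity at Bile acid receptor (Homo sapiens), read by AlphaScreen, with a stated time of 30 min; a higher number here means that more compound is needed for the effect, a lower number that less compound is needed:
compound 1 `Cc1ccccc1-n1nc(C)c2c1NC(=O)[C@H](C)S[C@@H]2c1ccc(-c2ccsc2)cc1`, 1400 nM
compound 2 `COc1ccccc1-c1ccc([C@H]2S[C@@H](C)C(=O)Nc3c2c(C)nn3-c2ccccc2C)cc1`, 1100 nM

For the measured compounds named here, compound 2 stands beside compound 1 with no separation beyond the scatter: the one measured step, a 1.3-fold lower number from compound 1 to compound 2 (0.10 log units; within the scatter), shows that swapping the aryl group at this position left the number essentially unchanged.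

Compound 3 `CCOc1cccc(-c2ccc([C@H]3S[C@@H](C)C(=O)Nc4c3c(C)nn4-c3ccccc3C)cc2)c1` continues from compound 2 with 3-ethoxyphenyl in place of 2-methoxyphenyl on an aromatic carbon. Going by the values given here, the only step that bears on this position, a 1.3-fold lower number from compound 1 to compound 2 (0.10 log units; within the scatter), was within the scatter, and no step varies an alkoxy group or its placement on the ring. The expected change in this assay is therefore none beyond the scatter, a 1.1-fold higher number from compound 2 to compound 3 (0.04 log units; within the scatter). Compound 3 is estimated at 1200 nM, between 500 nM and 3000 nM.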

Compound 3, half-maximal effective concentration: 3500 nM
Compound 3: the middle estimate sits 2.9-fold (0.46 log units) below what was measured; the whole stated range lies below it.
By their numbers in this assay, from the lowest: compounds 2 and 1 (each within the scatter of the next); then compound 3.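

In this assay this position proves not indifferent to the aryl group: 3-ethoxyphenyl brings a 3.2-fold higher number from compound 2 to compound 3 (0.50 log units; beyond the scatter) and also a 2.5-fold higher number from compound 1 to compound 3 (0.40 log units; beyond the scatter), whereas the earlier swap stayed within the scatter. The 3-ethoxyphenyl group is thus the first here to separate from the others, and it separates towards a higher number. Nothing available accounts for this shift.

The step from 2-methoxyphenyl alters both the alkoxy chain and its place on the ring, and these compounds cannot separate the two. Going by these compounds, whether an amine or a carboxylic acid on this aryl ring would lower the number remains open.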